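Giving Up a Large Side Group

The source may report more compounds than this note shows. Statements on the series, on what has been measured and on what is new or still open speak of the compounds shown alone.

Four compounds share one core: compound 1 (`CCOC(=O)CCN1CCN(c2c(F)cc3c(=O)c(C(=O)O)cn(C4CC4)c3c2OC)CC1C`), compound 2 (`CO/N=C(\C)CN1CCN(c2c(F)cc3c(=O)c(C(=O)O)cn(C4CC4)c3c2OC)CC1C`), compound 3 (`COc1c(N2CCN(C/C(C)=N/NC(=O)c3ccncc3)C(C)C2)c(F)cc2c(=O)c(C(=O)O)cn(C3CC3)c12`) and compound 4 (`COc1c(N2CCN(C/C(C)=N/O)C(C)C2)c(F)cc2c(=O)c(C(=O)O)cn(C3CC3)c12`). In an ADME assay on Vero cells (Chlorocebus sabaeus) for cytotoxicity, read by MTT assay, with a stated time of 72 h (on this read-out lower numbers stand for higher toxicity in this test and higher numbers for lower toxicity in this test), compound 1 has the entry "not determined" (no result reported) and so offers no number. Compound 2 gives 49.6 ug/mL and compound 3 gives 250 ug/mL as the higher of the two numbers available. The change to compound 4 is hydroxy in place of ((pyridin-4-yl)carbonyl)amino on a double-bonded nitrogen and puts hydroxy in place of ((pyridin-4-yl)carbonyl)amino on a double-bonded nitrogen. Among the measured compounds shown here, the only measured step that bears on this is a 5.0-fold higher number from compound 2 to compound 3 (0.70 log units; beyond the scatter) and it came with ((pyridin-4-yl)carbonyl)amino in place of methoxy on a double-bonded nitrogen. For the measured compounds named here, compound 4 gives that group up again, so it is expected to lose part of that rise and to move nearer compound 2 at 49.6 ug/mL even though no hydroxy compound has been measured. The step expected in this assay is a 3.1-fold lower number from compound 3 to compound 4 (0.49 log units; beyond the scatter) toward a lower number. For compound 4 the estimated value is 80 ug/mL with an expected range from 30 ug/mL to 220 ug/mL as a working guess.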

Compound 4, half-maximal cytotoxic concentration: 177 ug/mL
Estimate against measurement, compound 4: 2.2-fold (0.34 log units) below; low and high end bracket the measured number.
By their numbers in this assay, from the lowest: compound 2; then compounds 4 and 3 (each within the scatter of the next).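

In this assay, the swap of ((pyridin-4-yl)carbonyl)amino for hydroxy on the double-bonded nitrogen gives a 1.4-fold lower number from compound 3 to compound 4 (0.15 log units; within the scatter) and so does not separate the two compounds, even though the group that leaves has 9 heavy atoms and an aromatic ring and the one that enters has 1 heavy atom. The smaller edit of hydrogen in place of methyl on the oxygen gives a 3.6-fold higher number from compound 2 to compound 4 (0.55 log units; beyond the scatter) and so sets compound 2 apart from compound 4, which shows that this place responds to a single methyl. Nothing shown explains why these numbers differ.

From the compounds shown here alone, it stays open whether a longer chain on that oxygen, such as ethyl, would fall with compound 2. Going by these compounds, an amine on the double-bonded nitrogen is equally open.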